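Biphenyl to methoxy on a piperidinyl allylamine sigma ligand

The source may hold more compounds than are shown below. What is called first, only, known or untested is meant among the compounds shown, and "the series" means these compounds.

Measured compounds:
compound 1 `C/C(=C\CN1CCCCC1)c1ccccc1`, 459 nM;
compound 2 `COc1ccc(/C(C)=C/CN(C)C)cc1`, 806 nM;
compound 3 `C/C(=C\CN1CCCCC1)c1ccc(-c2ccccc2)cc1`, 0.86 nM.

In an assay on cell membranes for displacement of a labelled ligand from Sigma non-opioid intracellular receptor 1 (Cavia porcellus), read by scintillation counting, with a stated time of 150 min (on this read-out lower numbers stand for stronger inhibition and higher numbers for weaker inhibition), compound 3 gives the lowest number of the three, far below compound 1 and compound 2. Among the compounds with values here, the one step that bears on it is the addition of phenyl, a 530-fold lower number from compound 1 to compound 3 (2.73 log units; beyond the scatter). Compound 4 `COc1ccc(/C(C)=C/CN2CCCCC2)cc1` differs from compound 3 in that (methoxy in place of phenyl on an aromatic carbon). Within the data shown here, no measured pair isolates methoxy against phenyl; compound 2, which carries methoxy on a different amine, sits close to compound 1 in this assay. Removing the phenyl is therefore expected to give back most of that large step, so compound 4 is expected to show a 350-fold higher number from compound 3 to compound 4 (2.54 log units; beyond the scatter), with an estimated value of 300 nM in the range 80 nM to 1000 nM.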

Compound 4, inhibition constant: 14 nM
Beside the measured number, compound 4's estimate is 21-fold (1.33 log units) above it; the measured number lies below the stated range.
By their numbers in this assay, from the lowest: compound 3; then compound 4; then compounds 1 and 2 (each within the scatter of the next).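

Methoxy on this aromatic carbon does not behave like hydrogen: in this assay the change gives a 33-fold lower number from compound 1 to compound 4 (1.52 log units; beyond the scatter) and so keeps part of what phenyl gained, while methoxy in place of phenyl still gives a 16-fold higher number from compound 3 to compound 4 (1.21 log units; beyond the scatter) on the same core. The amine matters as well, with piperidin-1-yl in place of dimethylamino giving a 58-fold lower number from compound 2 to compound 4 (1.76 log units; beyond the scatter) in the methoxy series.

No evidence is given that explains these steps. From the compounds shown here alone, whether ethoxy or fluoro on this carbon, or morpholine in place of piperidin-1-yl, would hold the number remains open.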